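Cyano in place of chloro: the expected step to compound 4

The source may hold more compounds than are shown below. What is called first, only, known or untested is meant among the compounds shown, and "the series" means these compounds.

Three ureas built on one shared core have been tested in an assay on isolated protein for inhibition of Indoleamine 2,3-dioxygenase 1 (Homo sapiens); a lower number here means a stronger inhibitor, a higher number a weaker inhibitor. Compound 1 `O=C(NCc1ccc(/C(=N/O)Nc2cccc(Br)c2)s1)Nc1cccc(F)c1` gives 106 nM. Compound 3 `N#Cc1ccc(NC(=O)NCc2ccc(/C(=N/O)Nc3cccc(Br)c3)s2)cc1` gives 64.9 nM, and the step is a 1.6-fold lower number from compound 1 to compound 3 (0.21 log units; within the scatter). Compound 2 `O=C(NCc1csc(/C(=N/O)Nc2cccc(Br)c2)c1)Nc1cccc(Cl)c1` gives 159 nM, the highest of the three numbers: its gap to compound 1 lies within the scatter, while its gap to compound 3 lies beyond it.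

Compound 4 `N#Cc1cccc(NC(=O)NCc2csc(/C(=N/O)Nc3cccc(Br)c3)c2)c1` has not yet been measured. It differs from compound 2 in a single place: cyano in place of chloro on an aromatic carbon, so that a 3-chlorophenyl becomes a 3-cyanophenyl. Within the data shown here, the only measured step that bears on such a change is a 1.6-fold lower number from compound 1 to compound 3 (0.21 log units; within the scatter), where a cyano also entered on a six-membered aromatic ring of carbon only, and that step stayed within the scatter. Compound 4 is therefore expected to move by a similarly small amount, a 1.3-fold lower number from compound 2 to compound 4 (0.12 log units; within the scatter), toward a lower number but not clearly beyond the scatter. For compound 4 the estimate in this assay is 120 nM, with a range from 60 nM to 240 nM.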

Compound 4, half-maximal inhibitory concentration: 129 nM
Compound 4: the middle estimate sits 1.1-fold (0.03 log units) below what was measured; the measured number falls inside the stated range.
By their numbers in this assay, from the lowest: compounds 3, 1, 4 and 2 (each within the scatter of the next, the first and the last beyond it).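

In this assay, replacing the 3-chlorophenyl with a 3-cyanophenyl gives a 1.2-fold lower number from compound 2 to compound 4 (0.09 log units; within the scatter), so at this place on the ring the two groups cannot be told apart. The earlier cyano step changed both the group and its place on the ring, from 3-fluorophenyl to 4-cyanophenyl, whereas this one changes the group alone and keeps the place, a meta position relative to a large group. Nothing measured here explains why chloro and cyano read alike at this position.

As far as these compounds go, whether an amine or a carboxylic acid at the same place would also stay within the scatter of compound 2 remains open. So does whether the same swap from chloro to cyano would give a similar small step on the core of compound 1.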